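Replacing the 2-methylphenyl group of compound 2

A few compounds are considered here, and "the series" means these few. Any claim that something is new, unique, unknown or untested is made for them only; others in the source may bear on it.

In a functional assay on MCF7 cells (Homo sapiens) for inhibition, read by CCK-8 assay, with a stated time of 48 h (on this read-out higher numbers stand for weaker inhibition of growth and lower numbers for stronger inhibition of growth), compound 1 `Cc1ccccc1Nc1nc(Nc2ccccn2)ncc1Cl` reads 31400 nM and compound 3 `Cc1ccccc1Nc1nc(Nc2ccc(N3CCCCC3)cn2)ncc1Cl` reads 21400 nM while compound 2 `Cc1ccccc1Nc1nc(Nc2ccc(N3CCN(C)CC3)cn2)ncc1Cl` reads 5210 nM and stands lowest of the three. Compound 4 `CN1CCN(c2ccc(Nc3ncc(Cl)c(NCc4ccc(C(F)(F)F)cc4)n3)nc2)CC1` differs from compound 2 on a nitrogen on an aromatic ring (4-(trifluoromethyl)benzyl in place of 2-methylphenyl on a nitrogen on an aromatic ring). The three measured steps all concern a different group: a 6.0-fold lower number from compound 1 to compound 2 (0.78 log units; beyond the scatter) for 4-methylpiperazin-1-yl in place of hydrogen, a 1.5-fold lower number from compound 1 to compound 3 (0.17 log units; within the scatter) for piperidin-1-yl in place of hydrogen, and a 4.1-fold higher number from compound 2 to compound 3 (0.61 log units; beyond the scatter) for piperidin-1-yl in place of 4-methylpiperazin-1-yl. None touches the 2-methylphenyl, so they hint at a size but give no direction. In this assay the expected change is only a 1.2-fold higher number from compound 2 to compound 4 (0.06 log units; within the scatter) and no clear shift beyond the scatter is expected. For compound 4 the estimate is 6000 nM (expected range 1500 nM to 24000 nM).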

Compound 4, concentration for 50% growth inhibition: 28400 nM
The estimate for compound 4 lay 4.7-fold (0.68 log units) below the measured number; the whole stated range lies below it.
By their numbers in this assay, from the lowest: compound 2; then compounds 3, 4 and 1 (each within the scatter of the next).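

The group on a nitrogen on an aromatic ring is not a neutral site: in this assay, 4-(trifluoromethyl)benzyl in place of 2-methylphenyl gives a 5.5-fold higher number from compound 2 to compound 4 (0.74 log units; beyond the scatter). The 4-methylpiperazin-1-yl is kept in compound 4, so that group alone does not preserve the lower number of compound 2. Nothing measured here explains the rise.

As far as these compounds go, this single swap alters both the link to the ring and the ring's substituent, so their separate contributions remain open. An unsubstituted benzyl group at this nitrogen would begin to separate them.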